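This account rests on a few compounds, and the source may have more. Where it says the series, first, only, none or still open, it means among the compounds named here.

Values in an ADME assay on Akata cells (Homo sapiens) for cytotoxicity, with a stated time of 7 days (a lower number here means that less compound is tolerated, a higher number that more compound is tolerated), each one a limit and not a number:

- compound 1 `CNc1nc(N)nc2c1ncn2/C=C1/CC1(CO)CO`: > 24000 nM
- compound 2 `CCOc1nc(N)nc2c1ncn2/C=C1/CC1(CO)CO`: > 20000 nM
- compound 3 `Nc1nc(OCc2ccccc2)c2ncn(/C=C3/CC3(CO)CO)c2n1`: > 20000 nM

Compound 2 is known only by a limit, > 20000 nM. For the measured compounds named here, the other two values are limits as well, so no compound here has a measured half-maximal cytotoxic concentration.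

The next compound, compound 4 `Nc1nc(NC2CC2)c2ncn(/C=C3/CC3(CO)CO)c2n1`, has cyclopropylamino in place of the ethoxy of compound 2, on an aromatic carbon of a six-membered aromatic ring with 2 nitrogen: cyclopropylamino in place of ethoxy on an aromatic carbon.

Going by the values given here, three measured steps bear on this change: a step that the two limits leave unreadable from compound 1 to compound 2, a step that the two limits leave unreadable from compound 1 to compound 3 and a step that the two limits leave unreadable from compound 2 to compound 3. None of them has a readable size. Where compound 4 has cyclopropylamino, compound 1 has methylamino, and compound 1 gave only a limit, > 24000 nM. The data therefore give no reason to expect a step beyond the scatter in this assay, in either direction, and another limit is the likely result. The expected change is a step that the limit leaves unreadable from compound 2 to compound 4, a rough estimate. For compound 4 the estimated value is 22000 nM, with an expected range from 9000 nM to 60000 nM.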

Compound 4, half-maximal cytotoxic concentration: > 20000 nM
Compound 4 was reported as a limit; the forecaster's own chance of this, stated with the estimate: 75%; the middle value does not contradict the limit.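

Compound 4 is known in this assay only by a limit, > 20000 nM. Set against compound 1, compound 2 and compound 3, which are also known only by limits, it gives no step of readable size: the limit of > 20000 nM in this assay, at which 3 of the 4 values shown sit.

The compounds shown leave open where any half-maximal cytotoxic concentration lies, and whether the group on the aromatic carbon changes it at all.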